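The source may hold more compounds than are shown below. What is called first, only, known or untested is meant among the compounds shown, and "the series" means these compounds.

Of the compounds shown here, three with a shared core have been measured in a functional assay on HEK293 cells for agonist activity at G-protein coupled receptor 39 (Homo sapiens), read by scintillation proximity assay and inositol phosphate accumulation, with a stated time of 75 min; a higher number here means that more compound is needed for the effect, a lower number that less compound is needed. Compound 1 `Cc1nn(-c2ncnc3nc[nH]c23)c2c1C(OCCc1ccccc1)CC(=O)N2` carries a phenethyloxy group on a saturated ring carbon and gives 40 nM. Compound 3 `Cc1nn(-c2ncnc3nc[nH]c23)c2c1C(OC(=O)c1ccc(F)cc1)CC(=O)N2` holds a (4-fluorophenyl)carbonyl on that oxygen instead and gives 245 nM. Compound 2 `Cc1nn(-c2ncnc3nc[nH]c23)c2c1C(C(=O)N(C)c1nccs1)CC(=O)N2` replaces the oxygen-linked group with a methyl(1,3-thiazol-2-yl)carbamoyl and gives 3300 nM, the highest number of the three: compound 3 sits a 13-fold lower number from compound 2 to compound 3 (1.13 log units; beyond the scatter), and compound 1 is further still, with an 83-fold higher number from compound 1 to compound 2 (1.92 log units; beyond the scatter).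

Compound 4 `Cc1nn(-c2ncnc3nc[nH]c23)c2c1C(C(=O)NCc1ccc(F)cc1)CC(=O)N2` keeps the carbonyl of compound 2 but changes what hangs on it: (4-fluorobenzyl)amino in place of methyl(1,3-thiazol-2-yl)amino on a carbonyl carbon. The two steps that bear on this are the large ones already seen, from compound 1 to compound 2 and from compound 2 to compound 3, both showing that the carbamoyl with the thiazole is the weakest arrangement among these few. Compound 4 keeps an amide rather than an oxygen link, so a full return to the level of compound 1 is not expected, yet the move to a benzyl group with an amide hydrogen is expected to lower the number in this assay by a 5.5-fold lower number from compound 2 to compound 4 (0.74 log units; beyond the scatter). For compound 4 the expected value in this assay is therefore 600 nM, within a range from 150 nM to 3000 nM.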

Compound 4, half-maximal effective concentration: 1220 nM
The estimate for compound 4 lay 2.0-fold (0.31 log units) below the measured number; the range from low to high includes it.
By their numbers in this assay, from the lowest: compound 1; then compound 3; then compound 4; then compound 2.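

In this assay, the amide on this saturated ring carbon is not tied to the level of compound 2: changing only what hangs on the carbonyl carbon gives a 2.7-fold lower number from compound 2 to compound 4 (0.43 log units; beyond the scatter). This step is a modest one. This single swap alters several things together, since a five-membered aromatic ring with 2 hetero atoms gives way to a six-membered ring of carbon only and an amide hydrogen appears, and nothing shown says which of these changes counts, as no supporting measurement bears on the result. Even so, compound 4 at 1220 nM still has a higher number than compound 3 at 245 nM and compound 1 at 40 nM, so among these four compounds, both with the carbonyl bound directly to the ring carbon have higher numbers than both with an oxygen link.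

From the compounds shown here alone, what remains open is whether the amide hydrogen or the ring accounts for the step, a question that a 1,3-thiazol-2-ylamino group without the methyl could help to separate. Going by these compounds, whether an amide can come closer to compound 1 also remains open, and a longer chain such as phenethylamino on the carbonyl carbon would test that.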